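This account rests on a few compounds, and the source may have more. Where it says the series, first, only, none or still open, it means among the compounds named here.

Measured in a functional assay on DU-145 cells (Homo sapiens) for antiproliferative activity, read by sulforhodamine B assay, with a stated time of 3 days; a lower number here means a stronger inhibitor of growth, a higher number a weaker inhibitor of growth:
compound 1 `O=C(c1cccc(Nc2ncc(F)c(Nc3ccc(F)cc3)n2)c1)N1CCCCC1` gives 13000 nM;
compound 2 `CN(C)CC(=O)Nc1cccc(Nc2ncc(F)c(Nc3ccc(F)cc3)n2)c1` gives 1210 nM;
compound 3 `COCC(=O)Nc1cccc(Nc2ncc(F)c(Nc3ccc(F)cc3)n2)c1` gives 4460 nM.

Compound 3 stands second highest of these three numbers: compound 1 lies above it, as a 2.9-fold lower number from compound 1 to compound 3 (0.46 log units; beyond the scatter) shows, and compound 2 lies below it, as a 3.7-fold higher number from compound 2 to compound 3 (0.57 log units; beyond the scatter) shows. Compound 4 `CN1CCC(C(=O)Nc2cccc(Nc3ncc(F)c(Nc4ccc(F)cc4)n3)c2)CC1` differs from compound 3 in one place: 1-methylpiperidin-4-yl in place of methoxymethyl on a carbonyl carbon. The measured step that bears most directly on this change is a 3.7-fold higher number from compound 2 to compound 3 (0.57 log units; beyond the scatter), since compound 2 carries a dimethylamino where compound 4 carries a 1-methylpiperidin-4-yl, each replacing what compound 3 has; the larger step of an 11-fold lower number from compound 1 to compound 2 (1.03 log units; beyond the scatter) points the same way. For compound 4 a modest step down is therefore expected, a 3.0-fold lower number from compound 3 to compound 4 (0.47 log units; beyond the scatter). Compound 4 is expected to give about 1500 nM, within 400 nM to 5000 nM.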

Compound 4, concentration for 50% growth inhibition: 1150 nM
The estimate for compound 4 lay 1.3-fold (0.12 log units) above the measured number; measured number inside the range.
By their numbers in this assay, from the lowest: compounds 4 and 2 (each within the scatter of the next); then compound 3; then compound 1.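

In this assay, 1-methylpiperidin-4-yl on the carbonyl carbon in place of methoxymethyl gives the change (a 3.9-fold lower number from compound 3 to compound 4 (0.59 log units; beyond the scatter)), and the step to (dimethylamino)methyl (a 1.1-fold lower number from compound 2 to compound 4 (0.02 log units; within the scatter)) shows that the ring and that open chain cannot be told apart here. This position therefore accepts a six-membered ring, and the gain over the starting amide (an 11-fold lower number from compound 1 to compound 4 (1.05 log units; beyond the scatter)) survives it. No measurement here explains these steps. Still open, going by these compounds, is whether the ring nitrogen matters: a cyclohexyl or tetrahydropyran-4-yl group on the same carbonyl carbon would test this.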